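The source may hold more compounds than are shown below. What is called first, only, known or untested is meant among the compounds shown, and "the series" means these compounds.

Of the compounds shown here, three have so far been tested in a functional assay on NCI-H322M cells (Homo sapiens) for cytotoxicity, read by sulforhodamine B assay, with a stated time of 48 h; on this read-out lower numbers stand for stronger inhibition of growth and higher numbers for weaker inhibition of growth. Compound 1 `ClCc1ccc(Cn2cnc3c(Cl)ncnc32)cc1` gives 1820 nM, compound 2 `ClCc1cccc(Cn2cnc3nc(Cl)nc(Cl)c32)c1` gives 14100 nM, and compound 3 `ClCc1ccccc1Cn1cnc2nc(Cl)nc(Cl)c21` gives 4260 nM. Compound 3 thus stands second highest of the three, with compound 1 nearest and compound 2 furthest; both gaps lie beyond the usual scatter. Compound 4 `ClCc1ccccc1Cn1cnc2ncnc(Cl)c21` has not yet been measured. It differs from compound 3 in one place: hydrogen in place of chloro on an aromatic carbon. Going by the values given here, no two measured compounds differ in only one place, so no measured step guides this change; compound 1, which carries a single chloro on its core, gives the lowest number, but it also differs from compound 3 elsewhere. A small lowering is expected, a 1.6-fold lower number from compound 3 to compound 4 (0.21 log units; within the scatter), close to the scatter. Compound 4 is therefore estimated at 2600 nM, between 1000 nM and 7000 nM.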

Compound 4, concentration for 50% growth inhibition: 4670 nM
Compound 4: middle estimate off by 1.8-fold (0.25 log units), on the low side; the range from low to high includes it.
By their numbers in this assay, from the lowest: compound 1; then compounds 3 and 4 (each within the scatter of the next); then compound 2.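

In this assay, hydrogen in place of chloro on the aromatic carbon between two ring nitrogen atoms gives a 1.1-fold higher number from compound 3 to compound 4 (0.04 log units; within the scatter). Going by these compounds alone, this is the first change in a single place that can be read, and it shows that this read-out does not separate chloro from hydrogen at this position. No measured property is available to explain this result.

Going by these compounds, whether an amine or a methoxy group on this same carbon would move the number remains open. On these data alone, compound 1 differs from compound 4 in more than one place, so what sets their values apart also remains open.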